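The source may report more compounds than this note shows. Statements on the series, on what has been measured and on what is new or still open speak of the compounds shown alone.

Compound 1 `COc1ccc(-c2cccc(=O)n2-c2cc(OC)c(OC)c(OC)c2)cc1OCc1ccccc1`: 2310 nM
Compound 2 `COc1ccc(-c2cccc(=O)n2-c2cc(OC)c(OC)c(OC)c2)cc1`: < 10 nM
Compound 3 `COc1cc(-n2c(-c3ccc([N+](=O)[O-])cc3)cccc2=O)cc(OC)c1OC`: 201 nM

These three values come from a functional assay on SK-OV-3 cells (Homo sapiens) for cytotoxicity, read by spectrophotometry, with a stated time of 72 h (a higher number here means a weaker inhibitor, a lower number a stronger inhibitor), and describe compounds built on one shared core. Compound 2 gives < 10 nM, which is a limit of the assay and not a number. With that limit (the limit of < 10 nM in this assay, at which 1 of the 3 values shown sits), compound 2 is still the strongest of the three, since both of its steps lie beyond the scatter.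

Compound 4 `COc1cc(-n2c(-c3ccncc3)cccc2=O)cc(OC)c1OC` has not yet been measured. Its change from compound 2 is pyridin-4-yl in place of 4-methoxyphenyl on an aromatic carbon. Within the data shown here, two measured steps bear on this change, and neither swaps the whole group, so they guide only indirectly. The closer one is nitro in place of methoxy, which gave an at least 20-fold higher number from compound 2 to compound 3 (1.30 log units; beyond the scatter), a large rise in the number. Compound 4 also gives up that methoxy. The other, hydrogen in place of benzyloxy at the same group, gave an at least 230-fold lower number from compound 1 to compound 2 (2.36 log units; beyond the scatter), so edits here have moved the number strongly in both cases.

A large rise, meaning a weaker inhibitor, is therefore expected in this assay, estimated as an at least 30-fold higher number from compound 2 to compound 4 (1.47 log units; beyond the scatter) here. For compound 4 the expected value is 300 nM, with an estimated range from 60 nM to 1500 nM.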

Compound 4, half-maximal inhibitory concentration: 1790 nM
The estimate for compound 4 lay 6.0-fold (0.78 log units) below the measured number; measured number above the stated range.
By their numbers in this assay, from the lowest: compound 3; then compounds 4 and 1 (each within the scatter of the next). At a limit, below all of these: compound 2.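

Earlier edits at this position changed only a group on the ring, whereas here the whole 4-methoxyphenyl gives way to pyridin-4-yl, and in this assay that exchange gives an at least 170-fold higher number from compound 2 to compound 4 (2.25 log units; beyond the scatter), a large loss of strength. The size of this step is only a minimum, since compound 2 stands at a limit and not at a number: the limit of < 10 nM in this assay, at which 1 of the 4 values shown sits. With the methoxy already gone, pyridin-4-yl in place of 4-nitrophenyl still gives an 8.9-fold higher number from compound 3 to compound 4 (0.95 log units; beyond the scatter), a modest step beyond the scatter, so losing the methoxy does not by itself set the final level of compound 4.

Pyridin-4-yl differs from both earlier rings in two ways at once, a nitrogen in the ring and no group on it, and these compounds cannot show how much of the loss belongs to each. A plain phenyl group at this position would separate the two, and a phenyl ring carrying an amine or a carboxylic acid would show how far the number follows the group on the ring.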